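The compounds below may be only part of what the source reports. "The series", "measured", "known", "first", "only" and "open" are said of these compounds alone.

Compound 1 `CS(=O)(=O)c1ccc(C(=O)N2CCC(C(=O)N3CCN(c4ccc(F)cc4)CC3)CC2)cc1[N+](=O)[O-]` is known in an assay on isolated protein for inhibition of thyroid hormone receptor beta (Homo sapiens), read by fluorescence polarization (on this read-out higher numbers stand for weaker inhibition and lower numbers for stronger inhibition), only up to a limit: the value > 60000 nM marks the edge of the measurement, not a number. Compound 2 `CN(Cc1ccccc1F)C(=O)C1CCN(C(=O)c2ccc(S(C)(=O)=O)c([N+](=O)[O-])c2)CC1` likewise stops at a limit, > 60000 nM. For the measured compounds named here, compound 3 `CN(Cc1ccccc1F)C(=O)CNC(=O)c1ccc(S(C)(=O)=O)c([N+](=O)[O-])c1` is the one compound with a real number, giving 24000 nM in this assay. The rest of the picture is the limit of > 60000 nM in this assay, at which 2 of the 3 values shown sit. Compound 4 `CN(Cc1cccc(F)c1)C(=O)CNC(=O)c1ccc(S(C)(=O)=O)c([N+](=O)[O-])c1` differs from compound 3 by 3-fluorophenyl in place of 2-fluorophenyl on a saturated chain carbon bound to an amide-type nitrogen: the fluorine moves within the same ring, and nothing is added or removed. Going by the values given here, with no step between measured compounds to draw on, a change of this kind is expected to stay within the scatter, in neither direction. Compound 4 is therefore expected to give 24000 nM, between 8000 nM and 70000 nM, the expected step being no change at the digits printed from compound 3 to compound 4 (within the scatter).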

Compound 4, half-maximal inhibitory concentration: > 60000 nM
Compound 4 ended at the assay's limit (the forecaster's own chance of this, stated with the estimate: 30%); at least 2.5-fold (0.39 log units) between middle value and limit.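

Even with the same atoms, where the fluorine sits on this ring matters: 3-fluorophenyl in place of 2-fluorophenyl gives an at least 2.5-fold higher number from compound 3 to compound 4 (0.39 log units; beyond the scatter), so the change means weaker inhibition and not a neutral swap. The size of this step is only a lower bound, since the value for compound 4 is a limit and not a number. Compound 3 thus remains the only compound with a real number: the limit of > 60000 nM in this assay, at which 3 of the 4 values shown sit.

As far as these compounds go, how far compound 4 lies past that limit stays open. So does how a plain benzyl, a 2-chlorobenzyl or a longer chain would read in this place.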